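A few compounds are considered here, and "the series" means these few. Any claim that something is new, unique, unknown or untested is made for them only; others in the source may bear on it.

Working notes on the series. Compound 1 `CCn1c(-c2ccc(OCc3c(-c4c(Cl)cccc4Cl)noc3C(C)C)cc2)nc2ccc(C(=O)O)cc21` and compound 2 `CC(C)c1onc(-c2c(Cl)cccc2Cl)c1COc1ccc(-c2nc3ccc(C(=O)O)cc3n2C2CCC2)cc1` share one core and differ only in the group on the aromatic nitrogen. In an assay on Huh-7 cells for agonist activity at Bile acid receptor (Homo sapiens), read by a luciferase reporter (on this read-out lower numbers stand for an effect already at smaller amounts and higher numbers for an effect only at larger amounts of compound), compound 1 gives 2.31 nM, and compound 2 gives 14.4 nM. Among the measured compounds shown here, the single measured step, a 6.2-fold higher number from compound 1 to compound 2 (0.79 log units; beyond the scatter), leaves compound 2 at the higher of the two numbers, with compound 1 as its only neighbour. Compound 3 `CC(C)c1onc(-c2c(Cl)cccc2Cl)c1COc1ccc(-c2nc3ccc(C(=O)O)cc3n2Cc2ccc(F)cc2)cc1` is not yet measured; its change from compound 2 is 4-fluorobenzyl in place of cyclobutyl on an aromatic nitrogen. For the measured compounds named here, only the one measured step bears on this change, and only loosely: it shows that exchanging the group on this nitrogen can shift the read-out beyond the scatter, but it concerns a different pair of groups, and no analogue bearing a benzyl group has a number. Since the last exchange at this position moved the number upward, a further upward step is expected rather than a return toward compound 1, though with wide uncertainty. For compound 3 the expected step is a 2.4-fold higher number from compound 2 to compound 3 (0.39 log units; beyond the scatter). Compound 3 is estimated at 35 nM, with a range from 6 nM to 200 nM.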

Compound 3, half-maximal effective concentration: 3.31 nM
Estimate against measurement, compound 3: 11-fold (1.02 log units) above; the whole stated range lies above it.
By their numbers in this assay, from the lowest: compounds 1 and 3 (each within the scatter of the next); then compound 2.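

In this assay, among the compounds shown here, 4-fluorobenzyl on the aromatic nitrogen gives a 4.4-fold lower number from compound 2 to compound 3 (0.64 log units; beyond the scatter) and so reverses the direction of the only earlier exchange at this position, showing that a group with a six-membered aromatic ring is accepted here. Set against ethyl, the same group gives a 1.4-fold higher number from compound 1 to compound 3 (0.16 log units; within the scatter) and the two cannot be told apart, which leaves cyclobutyl in compound 2 as the only one of the three groups whose number stands apart from the others. Nothing at hand accounts for why cyclobutyl differs from ethyl and 4-fluorobenzyl.

The compounds shown leave open what the fluorine adds, which a plain benzyl group would settle, and whether the number holds with a longer link such as 2-phenylethyl. Also open, on these data alone, is whether cyclobutyl is a lone case or typical of saturated rings on this nitrogen, which cyclopropyl or cyclopentyl would test, and how a chain ending in an amine or a carboxylic acid would read.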